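Chloro for Hydrogen on the Phenyl Ring of Compound 2

This account rests on a few compounds, and the source may have more. Where it says the series, first, only, none or still open, it means among the compounds named here.

Measured compounds:
compound 1, `C/C(=N/O)c1ccc(NC(=O)Cn2nc(-c3ccccc3)nc2N)cc1`: 5.82%
compound 2, `c1ccc(-c2nc3sc(-c4ccccc4)cn3n2)cc1`: 25%

Of the compounds shown here, two have been tested in a functional assay on HOP-92 cells (Homo sapiens) for inhibition, read by sulforhodamine B assay, with a stated time of 48 h, tested at 10 uM; a higher number here means more inhibition of growth at the concentration tested, a lower number less inhibition of growth. Compound 1 gives 5.82%, and compound 2 gives 25%. Compound 2 therefore stands highest of the two numbers; its nearest neighbour, compound 1, lies lower by a gap that is beyond the usual scatter of the measurement. The two compounds share no common part that would let one read a single structural step between them, so their values can only be set side by side.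

Compound 3, `Clc1ccc(-c2cn3nc(-c4ccccc4)nc3s2)cc1`, has not yet been measured. It differs from compound 2 in one place: chloro in place of hydrogen on an aromatic carbon. Within the data shown here, no measured pair shows this change, so there is no precedent in these data for its size or direction. For this assay the step from compound 2 to compound 3 is expected to be small, a number 5 percentage points higher from compound 2 to compound 3 (within the scatter), leaning slightly upward but possibly not beyond the scatter. Compound 3 is accordingly estimated at 30%, within a range from 10% to 55%.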

Compound 3, percent growth inhibition at one concentration: 53%
Compound 3: the middle estimate sits 23 percentage points below what was measured; the range from low to high includes it.
By their numbers in this assay, from the lowest: compound 1; then compound 2; then compound 3.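

Among these compounds, the chloro group on an aromatic carbon of the six-membered aromatic ring, para to a large group, gives the first step that can be read in these data: in this assay the change is a number 28 percentage points higher from compound 2 to compound 3 (beyond the scatter) and it shows that this position does respond to substitution. Compound 1 and compound 2 could not show this, as they share no single structural step, whereas the change from phenyl to 4-chlorophenyl moves growth inhibition at the concentration tested by more than repeated measurements would account for. Nothing measured here bears on what lies behind the rise, so the step stands as an observation without an explanation.

From the compounds shown here alone, what remains open is whether the rise is particular to chloro or would also appear with another group on the same carbon, such as fluoro, methoxy, an amine or a carboxylic acid. Also open, going by these compounds, is whether chloro on another carbon of that ring would move the number in the same direction, as one step gives a single point and no trend.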